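The compounds below may be only part of what the source reports. "The series", "measured", "known", "first", "only" and "open" are said of these compounds alone.

Three compounds share one core and differ only in the group on the chain carbon bound to the double-bonded nitrogen. In a functional assay on the whole organism (strain albino) for inhibition, with Rattus norvegicus as the target, read by paw edema, with a stated time of 2 h, at a dose of 0.029 mmol/kg by the oral route (a lower number here means less inhibition, a higher number more inhibition at the dose given (going by the name of the read-out)), compound 1 `C/N=c1/c(C#N)c2n(c(=O)n1-c1ccccc1)CCC2` gives 26.5%, compound 2 `N#Cc1c2n(c(=O)n(-c3ccccc3)/c1=N\CCO)CCC2` gives 22.3%, and compound 3 `C=CC/N=c1/c(C#N)c2n(c(=O)n1-c1ccccc1)CCC2` gives 19%. On the numbers alone compound 2 sits in the middle of the three, yet the steps of a number 4.2 percentage points lower from compound 1 to compound 2 (within the scatter), a number 7.5 percentage points lower from compound 1 to compound 3 (within the scatter) and a number 3.3 percentage points lower from compound 2 to compound 3 (within the scatter) all lie within the scatter, so the three cannot be told apart. Compound 4 `CCCC/N=c1/c(C#N)c2n(c(=O)n1-c1ccccc1)CCC2` differs from compound 2 by ethyl in place of hydroxy on a saturated chain carbon, two bonds along the chain from a double-bonded nitrogen. Every change at this chain carbon so far has left the read-out unmoved beyond the scatter, so no step beyond the scatter is expected here either. Compound 4 is therefore estimated at 20% with a range from 8% to 32%, which means an expected step of a number 2.3 percentage points lower from compound 2 to compound 4 (within the scatter).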

Compound 4, a percentage reported as inhibition, in the whole organism at one dose (the size of the read-out at that dose, not a potency): 24%
For compound 4 the middle estimate is 4 percentage points below the measured one; low and high end bracket the measured number.
By their numbers in this assay, from the lowest: compounds 3, 2, 4 and 1 (each within the scatter of the next).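

Ethyl in place of hydroxy removes the one hydrogen-bond donor and one acceptor counted for the leaving group, yet this assay shows only a number 1.7 percentage points higher from compound 2 to compound 4 (within the scatter) for this change. The saturated propyl group behaves no differently, with a number 5 percentage points higher from compound 3 to compound 4 (within the scatter) when it replaces vinyl and a number 2.5 percentage points lower from compound 1 to compound 4 (within the scatter) when it replaces hydrogen. So far, this chain carbon accepts hydrogen, vinyl, hydroxymethyl and propyl without a readable shift, and no measurement at hand explains this. From the compounds shown here alone, whether an amine, a carboxylic acid or a phenyl ring on this chain would move the number beyond the scatter remains open.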